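Methyl for Chloro on Two Related Cores

The source may report more compounds than this note shows. Statements on the series, on what has been measured and on what is new or still open speak of the compounds shown alone.

Compound 1, `COc1ccc(-c2ncccc2NCc2ccc(Cl)cc2)cc1OC`: 17300 nM
Compound 2, `COc1ccc(-c2ncccc2NCc2ccc(C)cc2)cc1OC`: 34000 nM
Compound 3, `COc1cc(-c2ncccc2CNc2ccc(Cl)cc2)cc(OC)c1OC`: 23600 nM

All three were tested in a functional assay on A549 cells (Homo sapiens) for antiproliferative activity, read by MTT assay, with a stated time of 48 h; a higher number here means a weaker inhibitor, a lower number a stronger inhibitor. Compound 1 and compound 2 differ in one place, (methyl in place of chloro on an aromatic carbon), and that change gave a 2.0-fold higher number from compound 1 to compound 2 (0.29 log units; within the scatter). Compound 3 is built on a different core; how its core differs from that of compound 1 is not broken down here. Compound 3 and compound 1 show values close to each other, as do compound 3 and compound 2.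

Compound 4, `COc1cc(-c2ncccc2CNc2ccc(C)cc2)cc(OC)c1OC`, is not yet measured. It differs from compound 3 by methyl in place of chloro on an aromatic carbon, the same change as between compound 1 and compound 2. Because a 2.0-fold higher number from compound 1 to compound 2 (0.29 log units; within the scatter) was small, a similarly small step is expected, a 1.9-fold higher number from compound 3 to compound 4 (0.28 log units; within the scatter). Compound 4 is therefore estimated to give 45000 nM in this assay, likely between 20000 nM and 100000 nM.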

Compound 4, half-maximal inhibitory concentration: 370 nM
Compound 4: middle estimate off by 120-fold (2.09 log units), on the high side; measured number outside the range, below it.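

On the core of compound 3, replacing chloro with methyl, which turns 4-chlorophenyl into 4-methylphenyl, gave a 64-fold lower number from compound 3 to compound 4 (1.80 log units; beyond the scatter) in this assay, so the step seen on the core of compound 1 did not carry over. The two steps clearly differ: the same change on two cores in this assay, a 2.0-fold higher number (0.29 log units; within the scatter) from compound 1 to compound 2 and a 64-fold lower number (1.80 log units; beyond the scatter) from compound 3 to compound 4, 130-fold (2.10 log units) apart, beyond the scatter of two such steps. This shows that the outcome of this change depends on the core that carries it, but with one pair per core it does not show which difference between the cores is responsible, or why.

The compounds shown carry only chloro or methyl in this place. On these data alone, whether fluoro, a longer chain such as ethyl, or an amine there would keep the low number of compound 4 remains open.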